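Heteroaryl thioether series: thiazole to imidazole exchange

The source may report more compounds than this note shows. Statements on the series, on what has been measured and on what is new or still open speak of the compounds shown alone.

Measured compounds:
compound 1, `c1ccc(CCc2ccccc2CSc2nccs2)cc1`, 31%
compound 2, `Clc1ccc2[nH]c(SCc3ccccc3C#Cc3ccccc3)nc2c1`, 52%

For the measured compounds named here, in an assay on isolated protein for inhibition of Indoleamine 2,3-dioxygenase 1 (Homo sapiens), with a stated time of 60 min, tested at 10 uM (a higher number here means more inhibition at the concentration tested (going by the name of the read-out), a lower number less inhibition), compound 1 gives 31%, the lower of the two numbers measured so far. Compound 2 gives 52%, a number that lies above compound 1 by a gap beyond the usual scatter. Going by the values given here, compound 1 and compound 2 do not differ in a single place, so no step between measured compounds can be read from these two values, and nothing is known of how either compound binds.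

Among the compounds with values here, compound 3, `c1ccc(CCc2ccccc2CSc2ncc[nH]2)cc1`, is the first unmeasured compound. It differs from compound 1 in one place: 1H-imidazol-2-yl in place of 1,3-thiazol-2-yl on a sulfur. The difference keeps the same count of heavy atoms and the same ring size, and exchanges a hydrogen-bond acceptor for a hydrogen-bond donor.

Within the data shown here, no comparable step is available, so the expected step from compound 1 to compound 3 in this assay is a number 3 percentage points lower from compound 1 to compound 3 (within the scatter), judged as none beyond the scatter, with the range left wide. Compound 3 is estimated at 28%, between 5% and 55%.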

Compound 3, a percentage reported as inhibition, at one concentration (the size of the read-out at that concentration, not a potency): 19%
The estimate for compound 3 lay 9 percentage points above the measured number; the range from low to high includes it.
By their numbers in this assay, from the lowest: compound 3; then compound 1; then compound 2.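

In this assay, for the compounds shown here, 1H-imidazol-2-yl in place of 1,3-thiazol-2-yl on a sulfur gives a number 12 percentage points lower from compound 1 to compound 3 (beyond the scatter), the first change that can be read at a single place. The read-out at this position therefore depends on which five-membered aromatic ring sits on the sulfur, even with the heavy-atom count and ring size unchanged, and here the ring carrying a hydrogen-bond donor is the lower of the pair. Nothing measured here explains the drop.

Going by these compounds alone, compound 2 differs from compound 1 and from compound 3 in more than one place, so no step to it can be read, and the contributions of its other features remain unseparated. Still open, as far as these compounds go, is whether the step follows the loss of the ring sulfur or the arrival of the ring hydrogen on nitrogen, a question that 1-methyl-1H-imidazol-2-yl or 1,3-oxazol-2-yl on the same sulfur would address.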